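Swapping isobutyl for cyclohexyl on the aromatic ring

The source may hold more compounds than are shown below. What is called first, only, known or untested is meant among the compounds shown, and "the series" means these compounds.

In a functional assay on brain (Rattus norvegicus, strain Wistar) for inhibition (on this read-out higher numbers stand for weaker inhibition and lower numbers for stronger inhibition), compound 3 `Cc1[nH]c(=O)n(C2CCCCC2)c1-c1ccc(CC(C)C)cc1` gives 10900 nM as its reading. That is level, within the scatter, with compound 2 `Cc1[nH]c(=O)n(C)c1-c1ccc(CC(C)C)cc1` at 7800 nM and clearly lower than compound 1 `Cc1[nH]c(=O)n(C2CCCCC2)c1-c1ccccc1` at 47600 nM on the same scale. Compound 4 `Cc1[nH]c(=O)n(C2CCCCC2)c1-c1ccc(C2CCCCC2)cc1` has not yet been measured. It carries cyclohexyl in place of isobutyl on an aromatic carbon, para to a large group, which amounts to cyclohexyl in place of isobutyl on an aromatic carbon as the whole difference. Two measured steps offer some guidance. Putting isobutyl on that carbon in place of hydrogen gave a 4.4-fold lower number from compound 1 to compound 3 (0.64 log units; beyond the scatter) as a modest change, beyond the scatter. Changing the group on the aromatic nitrogen gave a 1.4-fold higher number from compound 2 to compound 3 (0.15 log units; within the scatter) at a different place, within the scatter. Within the data shown here, no measured pair swaps one group for another on that aromatic carbon, so no step beyond the scatter is expected in this assay in either direction. The estimated step of a 1.2-fold lower number from compound 3 to compound 4 (0.08 log units; within the scatter) therefore stays small. Compound 4 is expected near 9000 nM as a reading, with an estimated range from 3500 nM to 25000 nM as its likely span.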

Compound 4, half-maximal inhibitory concentration: 28900 nM
Compound 4: the middle estimate sits 3.2-fold (0.51 log units) below what was measured; the measured number lies above the stated range.
By their numbers in this assay, from the lowest: compounds 2 and 3 (each within the scatter of the next); then compounds 4 and 1 (each within the scatter of the next).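

Cyclohexyl in place of isobutyl on this aromatic carbon gives a 2.7-fold higher number from compound 3 to compound 4 (0.42 log units; beyond the scatter) in this assay, so the position tells these two all-carbon groups apart, and the drop in the number seen with isobutyl does not carry over to every such group. Measured against hydrogen, cyclohexyl gives a 1.6-fold lower number from compound 1 to compound 4 (0.22 log units; within the scatter) and stays within the scatter, so among the compounds shown, isobutyl lowers the number at this position and cyclohexyl does not. No measurement here accounts for the difference between the two groups.

The compounds shown leave open whether cyclopropyl, phenyl or a straight butyl chain would behave like isobutyl or like cyclohexyl on this carbon. They also leave open what an amine or a carboxylic acid would do there, and whether the difference between isobutyl and cyclohexyl holds with methyl on the aromatic nitrogen.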